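Trioxolane series on HL-60 cells: acid to hydroxamic acid

The compounds below may be only part of what the source reports. "The series", "measured", "known", "first", "only" and "open" are said of these compounds alone.

Measured so far:
- compound 1, `Oc1ccc(N[C@H]2CC[C@]3(CC2)OO[C@]2(O3)C3CC4CC(C3)CC2C4)c2cccnc12`; in a functional assay on HL-60 cells (Homo sapiens) for cytotoxicity, read by MTT assay, with a stated time of 48 h (a lower number here means a stronger inhibitor, a higher number a weaker inhibitor), compound 1 gives 8100 nM.
- compound 2, `O=C(O)[C@H]1CC[C@]2(CC1)OO[C@]1(O2)C2CC3CC(C2)CC1C3`; in this assay compound 2 returns only a limit, > 100000 nM.

Compound 2 stands at the edge of what this assay reports: its value is a limit, not a number, and the limit of > 100000 nM in this assay, at which 1 of the 2 values shown sits, marks that one of the two values shown sits there. Compound 1, carrying the aminophenol-bearing aromatic system on the shared core, gives a measured number, while the carboxylic acid of compound 2 does not.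

The next compound in the series is compound 3, `O=C(NO)[C@H]1CC[C@]2(CC1)OO[C@]1(O2)C2CC3CC(C2)CC1C3`, which differs from compound 2 by hydroxyamino in place of hydroxy on a carbonyl carbon.

Among the measured compounds shown here, no measured step exists between compounds that differ in one place, so the size of the step can only be anticipated. In this assay the expectation is a step downward, toward stronger inhibition, beyond the usual scatter but not large. Compound 3 is therefore expected to give about 30000 nM, in a range from 6000 nM to 100000 nM. The expected step, an at least 3.3-fold lower number from compound 2 to compound 3 (0.52 log units; beyond the scatter), is an estimate only, with a real chance that the assay again reports a limit.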

Compound 3, half-maximal inhibitory concentration: > 50000 nM
Compound 3: no number, only a limit (the forecaster's own chance of this, stated with the estimate: 40%); middle value at least 1.6-fold (0.22 log units) away from the limit.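

In this assay compound 3 gives only a limit, > 50000 nM. Compound 2 also gives only a limit, > 100000 nM. With limits for both compound 2 and compound 3, no step can be read for hydroxyamino in place of hydroxy on a carbonyl carbon. The compounds shown leave open how compound 2 and compound 3 actually compare.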